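This account rests on a few compounds, and the source may have more. Where it says the series, first, only, none or still open, it means among the compounds named here.

Measured so far:
compound 1 `Clc1cccc2c1C=C(CC1CN=CN1)CC2` — 50.1 nM
compound 2 `Fc1ccc2c(c1)C=C(CC1CN=CN1)CC2` — 50.1 nM
compound 3 `FC(F)(F)c1ccc2c(c1)C=C(CC1CN=CN1)CC2` — < 10000 nM

In a functional assay for binding affinity to Norepinephrine transporter (Rattus norvegicus), read by radioligand binding, in the presence of a further agent that is not named here (a lower number here means a stronger inhibitor, a higher number a weaker inhibitor), compound 1 gives 50.1 nM and compound 2 gives 50.1 nM, two values within the scatter of each other. Compound 3 is recorded in this assay only as a limit, < 10000 nM, so its exact standing is open; the shared core carries a trifluoromethyl in place of the fluoro of compound 2, and the step that the limit leaves unreadable from compound 2 to compound 3 cannot be read because of the limit of < 10000 nM in this assay, at which 1 of the 3 values shown sits.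

The next compound is compound 4 `Cc1ccc2c(c1)C=C(CC1CN=CN1)CC2`. It differs from compound 3 by methyl in place of trifluoromethyl on an aromatic carbon. Within the data shown here, no measured step bears directly on this exchange: the only step involving compound 3 is the unreadable one from compound 2, and compounds 1 and 2 show that two different single substituents on the aromatic ring of the core both give values in the same region. On that basis compound 4 is expected to fall near compounds 1 and 2 rather than at the limit, with the step that the limit leaves unreadable from compound 3 to compound 4 taken as a move from an undetermined position to a measurable value. The estimate for compound 4 in this assay is 80 nM, with a range from 20 nM to 400 nM.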

Compound 4, inhibition constant: 1000 nM
Estimate against measurement, compound 4: 13-fold (1.10 log units) below; the measured number lies above the stated range.
By their numbers in this assay, from the lowest: compounds 1 and 2 (each within the scatter of the next); then compound 4.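

In this assay, the aromatic carbon that is meta to a fused ring and para to a fused ring gives the series its first readable step at this position: methyl in place of fluoro gives a 20-fold higher number from compound 2 to compound 4 (1.30 log units; beyond the scatter). The outcome at this carbon therefore depends on which group it carries, and fluoro and methyl cannot be treated as interchangeable here. Compound 3 stands only as a limit, < 10000 nM, so the steps that involve it cannot be read, and the exchange of trifluoromethyl for methyl has no size because of this: the limit of < 10000 nM in this assay, at which 1 of the 4 values shown sits.

With only fluoro and methyl giving readable values at this carbon, two points define no trend, and where trifluoromethyl falls relative to them remains unsettled. As far as these compounds go, how a methoxy group, an amine or a longer chain at this carbon would read in this assay stays open, as does whether methyl in place of the chloro of compound 1 would give a step of similar size.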